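Working notes: halogenated aryl on the aromatic nitrogen

The source may hold more compounds than are shown below. What is called first, only, known or untested is meant among the compounds shown, and "the series" means these compounds.

Compound 1 `O=C(Nc1ccc(Oc2ccnc3[nH]ccc23)cc1)c1cn(-c2ccc(C(F)(F)F)cc2Cl)c2ccccc2c1=O` carries in a functional assay on HepG2 cells (Homo sapiens) for inhibition, read by MTT assay, with a stated time of 72 h (on this read-out lower numbers stand for stronger inhibition and higher numbers for weaker inhibition), only the entry "not determined" (no result reported), that is, no reported result. Compound 2 `Cn1ccc2c(Oc3ccc(NC(=O)c4cn(-c5ccccc5)c5ccccc5c4=O)cc3F)ccnc21` is therefore the only numbered entry: in this assay compound 2 gives 2170 nM, and with no second number beside it this value stands alone, neither high nor low against anything else in the series. Compound 3 `Cn1ccc2c(Oc3ccc(NC(=O)c4cn(-c5ccc(Br)cc5F)c5ccccc5c4=O)cc3F)ccnc21` has not yet been measured. It differs from compound 2 in one place: 4-bromo-2-fluorophenyl in place of phenyl on an aromatic nitrogen. For the measured compounds named here, no step between two measured compounds is available to set the size of such a change, so any expectation rests on compound 2 alone. The step expected in this assay is a 1.8-fold lower number from compound 2 to compound 3 (0.26 log units; within the scatter), a modest gain that could still fall within the scatter. Compound 3 is estimated at 1200 nM in this assay, with a range from 300 nM to 5000 nM.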

Compound 3, half-maximal inhibitory concentration: 2510 nM
The estimate for compound 3 lay 2.1-fold (0.32 log units) below the measured number; the range from low to high includes it.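

In this assay, the first step readable at this position is a 1.2-fold higher number from compound 2 to compound 3 (0.06 log units; within the scatter), so 4-bromo-2-fluorophenyl on the aromatic nitrogen, with 8 heavy atoms against the 6 of phenyl, leaves the number indistinguishable from that of compound 2. At this activity level, the position therefore accepts this pair of halogens without a difference that can be told from the scatter. Nothing measured here bears on the reason for this outcome.

For the compounds shown here, only one substituted aryl group can be read against phenyl, so the separate contributions of the fluorine and the bromine remain unknown. Also open, on these data alone, is whether a different kind of group at this position, such as an amine or a carboxylic acid on the phenyl ring, or a longer alkyl chain in place of the aryl group, would move the number beyond the scatter.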